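Trifluoromethyl in place of hydrogen: what to expect

The source may hold more compounds than are shown below. What is called first, only, known or untested is meant among the compounds shown, and "the series" means these compounds.

Of the compounds shown here, three have been measured so far in a functional assay on HeLa cells (Homo sapiens) for inhibition; on this read-out lower numbers stand for stronger inhibition and higher numbers for weaker inhibition. Compound 2 (`O=C/C=C/n1ccc(=O)[nH]c1=O`) gives 30000 nM. Compound 3 (`Cc1cn(C)c(=O)n(/C=C/C=O)c1=O`) gives 15000 nM, which lies within the usual scatter of compound 2, so these two cannot be told apart. Compound 1 (`Cc1cn(/C=C/C=O)c(=O)[nH]c1=O`) gives 100000 nM, a clearly higher number and so weaker inhibition than either of the other two.

The next compound, compound 4 (`O=C/C=C/n1cc(C(F)(F)F)c(=O)[nH]c1=O`), has not been measured yet. It differs from compound 2 by a single change: trifluoromethyl in place of hydrogen on an aromatic carbon. In words, this is trifluoromethyl in place of hydrogen on an aromatic carbon.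

Going by the values given here, only one measured step bears on this change, as compound 1 carries methyl on that same aromatic carbon: a 3.3-fold lower number from compound 1 to compound 2 (0.52 log units; beyond the scatter). This modest step lies beyond the scatter and shows the lower number with hydrogen at that carbon. Read in reverse, it hints that replacing this hydrogen could raise the number. Among the compounds with values here, no measured compound carries trifluoromethyl, however, so this single step is only a loose guide. The expected result is a small rise, possibly within the scatter: a 1.5-fold higher number from compound 2 to compound 4 (0.18 log units; within the scatter). For compound 4 the estimated value is 45000 nM, with an expected range from 12000 nM to 130000 nM.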

Compound 4, half-maximal inhibitory concentration: > 100000 nM
Compound 4: no number, only a limit (the forecaster's own chance of this, stated with the estimate: 15%); middle value at least 2.2-fold (0.34 log units) from the limit.
By their numbers in this assay, from the lowest: compounds 3 and 2 (each within the scatter of the next); then compound 1.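

In this assay compound 4 gives > 100000 nM, which is a limit of the assay and not a number. Even so, the change has a readable direction and a minimum size: trifluoromethyl in place of hydrogen on this aromatic carbon gives an at least 3.3-fold higher number from compound 2 to compound 4 (0.52 log units; beyond the scatter). Until now only methyl had been seen on this carbon, so this is the second group there that goes with weaker inhibition than hydrogen. Trifluoromethyl in place of methyl on this carbon gives a number no lower from compound 1 to compound 4 (the limit leaves the size open) and so the step between the two groups themselves cannot be read any further, as the limit leaves its size open: the limit of > 100000 nM in this assay, at which 1 of the 4 values shown sits.

The compounds shown carry only hydrogen, methyl and trifluoromethyl on this aromatic carbon, so it remains open whether a different group there, such as an amine, a carboxylic acid or a single fluorine atom, would give a lower number than hydrogen does. Going by these compounds, the full size of the step from hydrogen to trifluoromethyl also remains open, and with it how much weaker compound 4 really is than the compounds that have an actual number.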